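The source may report more compounds than this note shows. Statements on the series, on what has been measured and on what is new or still open speak of the compounds shown alone.

Measured so far, all in a functional assay (Homo sapiens) for inhibition of Nucleic Acid, tested at 100 uM; on this read-out lower numbers stand for less inhibition and higher numbers for more inhibition at the one concentration tested (going by the name of the read-out):
- compound 1, `[N-]=[N+]=Nc1nccc2ncn([C@H]3C[C@H](O)[C@@H](CO)O3)c12`: compound 1 gives 14%
- compound 2, `Clc1[nH]ccc2ncnc1-2`: compound 2 gives 6%
- compound 3, `CN(C)c1nccc2c1ncn2C1O[C@H](CO)[C@@H](O)[C@H]1O`: compound 3 gives 0%

Compound 2 holds the second highest of the three numbers; its nearest neighbour is compound 3, and its furthest is compound 1, and both of those gaps lie within the scatter, so the three measured numbers cannot be told apart.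

Compound 4, `CCNc1[nH]ccc2ncnc1-2`, is unmeasured. It differs from compound 2 in one place: ethylamino in place of chloro on an aromatic carbon. Going by the values given here, no step between measured compounds is available to calibrate this change; the set contains no pair that differs in one place. The expectation in this assay is therefore a step of no size beyond the scatter, in no particular direction, and the estimate of a number 2 percentage points higher from compound 2 to compound 4 (within the scatter) rests only on the low numbers of compounds 1 to 3. Compound 4 is expected to give 8%, in a range from 0% to 25%.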

Compound 4, a percentage reported as inhibition, at one concentration (the size of the read-out at that concentration, not a potency): 3%
The estimate for compound 4 lay 5 percentage points above the measured number; measured number inside the range.
By their numbers in this assay, from the lowest: compounds 3, 4, 2 and 1 (each within the scatter of the next, the first and the last beyond it).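

In this assay, ethylamino in place of chloro on an aromatic carbon next to the ring nitrogen gives a number 3 percentage points lower from compound 2 to compound 4 (within the scatter), the first one-place step available in the series. At this position, the two groups therefore cannot be told apart at the one concentration tested, despite the hydrogen-bond donor and acceptor that ethylamino brings. No measurement here gives a cause for this step.

On these data alone, whether an unsubstituted amine, a carboxylic acid or a longer alkyl chain at this position would give a step beyond the scatter remains open. Also open, as far as these compounds go, is whether the ethylamino for chloro step would read the same on the cores of compound 1 and compound 3.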